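The source may report more compounds than this note shows. Statements on the series, on what has been measured and on what is new or still open speak of the compounds shown alone.

Compound 1 `CC(C)Cc1ccc(C(C)C2(O)CSC2)cc1` gives 7600 nM in an assay on cells for inhibition of Polyunsaturated fatty acid 5-lipoxygenase (Rattus norvegicus), read by LC-MS, with stated times of 2 h and 15 min (a lower number here means a stronger inhibitor, a higher number a weaker inhibitor), and holds the lower of the two numbers in hand: compound 2 `CC(C)Cc1ccc(C(C)C2(O)CS(=O)(=O)C2)cc1` gives 20200 nM in this assay, a higher number beyond the scatter. Compound 3 `CC(C)Cc1ccc(C(C)c2nnn[nH]2)cc1` differs from compound 1 by a group of 5 heavy atoms (1 carbon, 4 nitrogen; one five-membered aromatic ring with 4 hetero atoms) in place of a group of 5 heavy atoms (3 carbon, 1 oxygen, 1 sulfur; one four-membered non-aromatic ring with 1 hetero atom), on a saturated chain carbon bound to an aromatic carbon and a saturated chain carbon. Going by the values given here, no measured step bears on this kind of exchange, so the direction is open; a modest loss is expected, with a step from compound 1 to compound 3 of about a 1.4-fold higher number from compound 1 to compound 3 (0.16 log units; within the scatter) in this assay. Compound 3 is estimated at 11000 nM in this assay, within a range of 3000 nM to 40000 nM.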

Compound 3, half-maximal inhibitory concentration: > 100000 nM
Compound 3 gave a limit, no number; the forecaster's own chance of this, stated with the estimate: 15%; at least 9.0-fold (0.95 log units) between middle value and limit.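

Compounds 1 and 2 varied only the four-membered ring, whereas this change replaces it outright and shows that the position does not tolerate every group of equal heavy-atom count. In this assay, 1H-tetrazol-5-yl in its place gives an at least 13-fold higher number from compound 1 to compound 3 (1.11 log units; beyond the scatter). The reading for compound 3 is a limit of the assay, not a number: the limit of > 100000 nM in this assay, at which 1 of the 3 values shown sits.

On these data alone, its true size therefore remains open. Also open, as far as these compounds go, is whether a carboxylic acid or an amine on this saturated chain carbon would fare any better than the tetrazole.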